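The compounds below may be only part of what the source reports. "The series", "measured", "known", "first", "only" and "open" are said of these compounds alone.

Of the compounds shown here, three sharing one core have so far been measured in a functional assay on SH-SY5Y cells (Homo sapiens) for inhibition, read by sulforhodamine B assay; on this read-out higher numbers stand for weaker inhibition and lower numbers for stronger inhibition. Compound 1 (`COC(=O)CC/C(C)=C/Cc1c(OC)c(C)c2c(c1OCC#CCN1CCN(c3ccccc3F)CC1)C(=O)OC2`) gives 35800 nM. Compound 2 (`COC(=O)CC/C(C)=C/Cc1c(OC)c(C)c2c(c1OCC#CCN1CCC(C(=O)OC)CC1)C(=O)OC2`) gives 41200 nM, which lies within the scatter of the value of compound 1. Compound 3 (`COC(=O)CC/C(C)=C/Cc1c(OC)c(C)c2c(c1OCC#CCN1CCC(c3ccccc3)c3ccccc31)C(=O)OC2`) gives 6450 nM, a lower number than that of compound 1 by more than the scatter, so compound 1 stands with compound 2 on the weaker side of this small set.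

The next compound to be tested is compound 4 (`COC(=O)CC/C(C)=C/Cc1c(OC)c(C)c2c(c1OCC#CCN1CCN(c3ccc(C)cc3)CC1)C(=O)OC2`). It comes from compound 1 by putting 4-methylphenyl in place of 2-fluorophenyl on an amine nitrogen in a ring. No two measured compounds differ in only one place, so the data give no direct guide to a step of this kind in this assay. Compound 3 differs from compound 1 by far more than this exchange, so it says little about the size of the step. The expectation therefore rests on compound 1 at 35800 nM, with no step beyond the scatter foreseen. The estimated step of a 1.2-fold lower number from compound 1 to compound 4 (0.08 log units; within the scatter) is expected to be small. For compound 4 the estimated value is 30000 nM, with an expected range from 12000 nM to 65000 nM.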

Compound 4, half-maximal inhibitory concentration: 37700 nM
For compound 4 the middle estimate is 1.3-fold (0.10 log units) below the measured one, within the range that was stated.
By their numbers in this assay, from the lowest: compound 3; then compounds 1, 4 and 2 (each within the scatter of the next).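

In this assay, within the data shown here, the exchange of 2-fluorophenyl for 4-methylphenyl on an amine nitrogen in a ring gives the first step in this set that can be read at a single place: a 1.1-fold higher number from compound 1 to compound 4 (0.02 log units; within the scatter). At this position, therefore, these two groups, each with one six-membered aromatic ring of carbon only and the same count of heavy atoms, cannot be told apart on this read-out. This one pair alters the substituent and its numbered place on the phenyl ring together, so it gives no separate reading of either, and nothing at hand offers an explanation for the result.

A 4-fluorophenyl or 2-methylphenyl group at the same ring nitrogen would be needed to read the substituent and its numbered place separately. From the compounds shown here alone, it also remains open whether a group of another kind there, such as a benzyl group, a pyridine ring or a phenyl ring carrying a carboxylic acid, would give a step beyond the scatter.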